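A few compounds are considered here, and "the series" means these few. Any claim that something is new, unique, unknown or untested is made for them only; others in the source may bear on it.

Working notes on the series. The shared core is carried unchanged through compounds 1, 2 and 3; only the group on the amide-type nitrogen varies. Compound 1 `N#Cc1ccc(NC(=O)CN2C(=O)/C(=C/c3ccc(-c4ccc(Cl)cc4)o3)SC2=S)cc1` gives 90000 nM in a functional assay on REH cells (Homo sapiens) for cytotoxicity, read by MTT assay, with a stated time of 72 h; a lower number here means a stronger inhibitor, a higher number a weaker inhibitor. Compound 3 `O=C(CN1C(=O)/C(=C/c2ccc(-c3ccc(Cl)cc3)o2)SC1=S)Nc1nnn[nH]1` gives 50000 nM in this assay, and a 1.8-fold lower number from compound 1 to compound 3 (0.26 log units; within the scatter). Compound 2 `N#Cc1cc(NC(=O)CN2C(=O)/C(=C/c3ccc(-c4ccc(Cl)cc4)o3)SC2=S)ccc1C(F)(F)F` reaches only a limit in this assay, namely > 250000 nM. For compound 2 there is thus no number, only (the limit of > 250000 nM in this assay, at which 1 of the 3 values shown sits). The two steps that reach compound 2 or leave it are both beyond the scatter: an at least 2.7-fold higher number from compound 1 to compound 2 (0.44 log units; beyond the scatter), and an at least 5.0-fold lower number from compound 2 to compound 3 (0.69 log units; beyond the scatter). Compound 2 therefore stands at the weak end of the three.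

Compound 4 `CCCCCCNC(=O)CN1C(=O)/C(=C/c2ccc(-c3ccc(Cl)cc3)o2)SC1=S` has not yet been measured. It differs from compound 2 by hexyl in place of 3-cyano-4-(trifluoromethyl)phenyl on an amide-type nitrogen. Among the compounds with values here, no measured step involves hexyl. Within the data shown here, the only step that bears directly on the direction is the one leaving compound 2, an at least 5.0-fold lower number from compound 2 to compound 3 (0.69 log units; beyond the scatter), and both changes away from the group on compound 2 reach a number rather than a limit. Since compound 2 is itself only a limit, the size of the step is uncertain. For compound 4 the number in this assay is therefore expected to be lower, an at least 2.5-fold lower number from compound 2 to compound 4 (0.39 log units; beyond the scatter). The estimate for compound 4 is 100000 nM, within 30000 nM to 250000 nM.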

Compound 4, half-maximal inhibitory concentration: 55000 nM
Beside the measured number, compound 4's estimate is 1.8-fold (0.26 log units) above it; the measured number falls inside the stated range.
By their numbers in this assay, from the lowest: compounds 3, 4 and 1 (each within the scatter of the next). At a limit, above all of these: compound 2.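

Compound 4 puts a hexyl, which has no ring, on the amide-type nitrogen, and in this assay it cannot be told apart from the two ring-bearing groups: a 1.1-fold higher number from compound 3 to compound 4 (0.04 log units; within the scatter), and a 1.6-fold lower number from compound 1 to compound 4 (0.21 log units; within the scatter). A ring at this place is therefore not needed to reach this range, although compounds 1, 3 and 4 do not make the position indifferent, as compound 2 goes against that reading with an at least 4.5-fold lower number from compound 2 to compound 4 (0.65 log units; beyond the scatter). On these data alone, compound 2 carries only a limit, so the size of that step stays open: the limit of > 250000 nM in this assay, at which 1 of the 4 values shown sits.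

As far as these compounds go, whether a shorter or longer alkyl chain, or a chain ending in an amine or a carboxylic acid, would move the number beyond the scatter remains open. Also open, from the compounds shown here alone, is what a phenyl bearing trifluoromethyl alone would give.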